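The source may hold more compounds than are shown below. What is called first, only, known or untested is meant among the compounds shown, and "the series" means these compounds.

Compound 1 `COc1cc(-c2nc3ccccc3s2)ccc1OCC(=O)NNC(=O)CN[C@@H](CCSC)C(=O)O`: 1950 nM
Compound 2 `CCOC(=O)[C@H](CS(=O)(=O)O)NCC(=O)NNC(=O)COc1ccc(-c2nc3ccccc3s2)cc1OC`: 1990 nM
Compound 3 `CCOC(=O)[C@H](CCSC)NCC(=O)NNC(=O)COc1ccc(-c2nc3ccccc3s2)cc1OC`: 1760 nM

These three values come from a functional assay on MCF7 cells (Homo sapiens) for inhibition, read by MTT assay, with a stated time of 3 days (a lower number here means a stronger inhibitor, a higher number a weaker inhibitor), and they cannot be told apart. Compound 3 stands level with the other two, as a 1.1-fold lower number from compound 1 to compound 3 (0.04 log units; within the scatter) and a 1.1-fold lower number from compound 2 to compound 3 (0.05 log units; within the scatter) show.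

Compound 4 `CCOC(=O)[C@@H]1CCCN1CC(=O)NNC(=O)COc1ccc(-c2nc3ccccc3s2)cc1OC` keeps the core of compound 3 and changes one group: 2-(ethoxycarbonyl)pyrrolidin-1-yl in place of (1-(ethoxycarbonyl)-3-(methylsulfanyl)propyl)amino on a saturated chain carbon bound to a carbonyl carbon. The open chain with its methylsulfanyl group gives way to a five-membered non-aromatic ring, which also holds the amine nitrogen.

Among the measured compounds shown here, three measured steps bear on this. Exchanging sulfo for (methylsulfanyl)methyl gave a 1.1-fold lower number from compound 2 to compound 3 (0.05 log units; within the scatter), adding the ethyl gave a 1.1-fold lower number from compound 1 to compound 3 (0.04 log units; within the scatter), and the larger exchange of the whole group on the amine nitrogen gave a 1.0-fold higher number from compound 1 to compound 2 (0.01 log units; within the scatter). All three stayed within the scatter. None of them introduces a ring, so the data leave this change untested, and the range is kept wide.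

The expected change is a 1.1-fold higher number from compound 3 to compound 4 (0.03 log units; within the scatter), with no step beyond the scatter anticipated. For compound 4 the estimated value is 1900 nM, within an expected range of 1000 nM to 3600 nM.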

Compound 4, half-maximal inhibitory concentration: 770 nM
For compound 4 the middle estimate is 2.5-fold (0.39 log units) above the measured one; the whole stated range lies above it.
By their numbers in this assay, from the lowest: compound 4; then compounds 3, 1 and 2 (each within the scatter of the next).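

In this assay, among the compounds shown here, the 2-(ethoxycarbonyl)pyrrolidin-1-yl group is the first change at this position to go beyond the scatter, with a 2.3-fold lower number from compound 3 to compound 4 (0.36 log units; beyond the scatter), a 2.6-fold lower number from compound 2 to compound 4 (0.41 log units; beyond the scatter) and a 2.5-fold lower number from compound 1 to compound 4 (0.40 log units; beyond the scatter). Compounds 1, 2 and 3 stand level despite their different open-chain groups, so this position does respond to change, and here the response comes with the five-membered non-aromatic ring that holds the amine nitrogen. Nothing available accounts for this step.

The ring comes together with the loss of the hydrogen-bond donor, 1 in the leaving group and 0 in the entering one, so the shown compounds cannot separate these two differences. On these data alone, an open-chain tertiary N-methyl amine would bear on that, while a piperidine ring or a pyrrolidine carrying a free carboxylic acid in place of the ethyl ester remains open.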